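This account rests on a few compounds, and the source may have more. Where it says the series, first, only, none or still open, it means among the compounds named here.

Compound 1, `CCc1c(-c2ccc(OC)cc2)noc1-c1ccc(OC)cc1`, is reported in an ADME assay on HMEC-1 cells (Homo sapiens) for antiproliferative activity, read by cell counting, with a stated time of 5 days (on this read-out lower numbers stand for stronger inhibition and higher numbers for weaker inhibition), only as the limit > 100000 nM.
Compound 2, `COc1ccc(-c2cc(-c3ccc([N+](=O)[O-])cc3)on2)cc1`, is reported in this assay only as the limit > 100000 nM.
Compound 3, `Oc1ccc(-c2cc(-c3ccc(O)cc3)on2)cc1`, gives in this assay a value of 6300 nM.

Going by the values given here, compound 3 is thus the one compound of the three with a number in this assay; the other two sit at the limit of > 100000 nM in this assay, at which 2 of the 3 values shown sit, so no comparison of its size with them can be drawn beyond the fact that compound 3 alone gave a reading. Compound 4, `Cc1c(-c2ccc(O)cc2)noc1-c1ccc(O)cc1`, has not yet been measured in this assay. It differs from compound 3 in one place: methyl in place of hydrogen on an aromatic carbon. Among the compounds with values here, no measured pair shows what such a change does here, so the expectation rests on compound 3 alone. The step of a 1.1-fold lower number from compound 3 to compound 4 (0.02 log units; within the scatter) is expected to be small, in no particular direction, and to stay within the usual scatter of repeated measurements. Compound 4 is therefore estimated at 6000 nM, with a range from 2000 nM to 20000 nM.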

Compound 4, half-maximal inhibitory concentration: 47000 nM
The estimate for compound 4 lay 7.8-fold (0.89 log units) below the measured number, and the stated range ends below it.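

Placing a methyl on this aromatic carbon of the five-membered ring, two ring bonds from the ring nitrogen and two from the ring oxygen, gives in this assay a 7.5-fold higher number from compound 3 to compound 4 (0.87 log units; beyond the scatter). Going by these compounds alone, this is the first pair in the set that differs in one place, and it shows that this carbon does not tolerate the change without loss: a single added carbon weakens inhibition beyond the scatter. Nothing measured here tells why the methyl has this effect.

On these data alone, whether a chlorine, an amine or a carboxylic acid on this carbon would behave as the methyl does remains open. Also open, as far as these compounds go, is whether the same step would appear with other groups in place of the two groups of 7 heavy atoms.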